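Metabolic stability notes: pyrazolyl to allyloxy swap

The source may hold more compounds than are shown below. What is called first, only, known or untested is meant among the compounds shown, and "the series" means these compounds.

Measured so far:
compound 1, `Cc1cc(-n2cccn2)cc(C(=O)NNS(=O)(=O)c2ccccc2)c1F`: 23 uL/min
compound 2, `O=C(NNS(=O)(=O)c1ccccc1F)c1cccc(-n2cccn2)c1`: 12 uL/min

For the measured compounds named here, only two compounds have numbers in an ADME assay on microsomes from liver (Homo sapiens) for metabolic stability, read by HPLC, using NADPH, with a stated time of 60 min, tested at 1 uM, in the presence of a further agent that is not named here; on this read-out higher numbers stand for fast clearance and lower numbers for slow clearance. Compound 1 has the higher of the two, yet compound 2 sits within the usual scatter of it, so the pair shows no real separation and gives no foothold for a trend. Going by the values given here, no two measured compounds differ in a single place, so no step between measured compounds is on record.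

Compound 3, `C=CCOc1cc(C)c(F)c(C(=O)NNS(=O)(=O)c2ccccc2)c1`, is the next compound to go into this assay. Relative to compound 1 the change is allyloxy in place of 1H-pyrazol-1-yl on an aromatic carbon.

With nothing comparable measured, the expectation for compound 3 leans on the value of compound 1 alone. The step from compound 1 to compound 3 is expected to be small and, if anything, toward faster clearance, a 1.4-fold higher number from compound 1 to compound 3 (0.16 log units; within the scatter), which is not expected to exceed the scatter. The estimate for compound 3 in this assay is 33 uL/min, with a likely range from 14 uL/min to 80 uL/min.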

Compound 3, intrinsic clearance in a liver preparation (reported as CLH), per the amount of preparation that the assay uses: 73 uL/min
Compound 3: the middle estimate sits 2.2-fold (0.34 log units) below what was measured; the range from low to high includes it.
By their numbers in this assay, from the lowest: compounds 2 and 1 (each within the scatter of the next); then compound 3.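

For the compounds shown here, at this position, on an aromatic carbon para to the fluoro group and meta to the methyl group, the group present makes a readable difference in this assay: allyloxy in place of 1H-pyrazol-1-yl gives a 3.2-fold higher number from compound 1 to compound 3 (0.50 log units; beyond the scatter) and is the only step on record so far. The earlier pair could not show this, as its two compounds differ in more than one place and their values lie within the scatter of each other. Going by these compounds alone, nothing on hand accounts for the step, so the single swap gives its size and direction but no reason for it.

The swap removes a five-membered aromatic ring and brings in an open group with a double bond outside aromatic rings, and this one pair cannot separate those two features, which a propoxy chain, a methoxy group or a dimethylamino group at the same place would begin to do. Going by these compounds, it also remains open whether the same swap gives a step of similar size on the core of compound 2.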